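The source may hold more compounds than are shown below. What is called first, only, known or untested is meant among the compounds shown, and "the series" means these compounds.

Going by the values given here, compound 2 `CCN1CCC(C(=O)Nc2cc(Cl)c(N)cc2OC)CC1` is one of two compounds measured in a functional assay on the whole organism for antagonist activity, with Mus musculus as the target; a higher number here means that more compound is needed for the effect, a lower number that less compound is needed. For compound 2 the assay gives only a limit, > 10 mg/kg. Its neighbour, compound 1 `COc1cc(N)c(Cl)cc1NC(=O)C1CCN(Cc2ccccc2Cl)CC1`, differs at a single place, a 2-chlorophenyl in place of the methyl on the saturated chain carbon bound to the ring amine nitrogen. For compound 1 this assay likewise gives only a limit, > 4 mg/kg. The step that the two limits leave unreadable from compound 1 to compound 2 therefore cannot be read: compound 1 sits at the limit of > 4 mg/kg in this assay, at which 1 of the 2 values shown sits, and compound 2 at the limit of > 10 mg/kg in this assay, at which 1 of the 2 values shown sits, so nothing shows whether either substituent changes the dose.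

Compound 3 `COc1cc(N)c(Cl)cc1NC(=O)C1CCN(Cc2ccc(F)cc2)CC1` is the next compound, not yet measured. It carries 4-fluorophenyl in place of methyl on a saturated chain carbon bound to an amine nitrogen in a ring. Among the compounds with values here, the only measured step that bears on this change is the unreadable one from compound 1 to compound 2, where an aryl group on the same carbon also left the dose at a limit. With both measured compounds at limits, no direction in this assay can be drawn from the data, and compound 3 is expected to land near the same limits, with the step of a number no higher from compound 2 to compound 3 (the limit leaves the size open) estimated as none beyond the scatter. The estimate for compound 3 in this assay is 10 mg/kg, between 3 mg/kg and 30 mg/kg.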

Compound 3, dose for half-maximal effect: 0.6 mg/kg
Estimate against measurement, compound 3: 17-fold (1.22 log units) above, outside the stated range (below it).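

In this assay, 4-fluorophenyl in place of methyl on a saturated chain carbon bound to an amine nitrogen in a ring gives an at least 16-fold lower number from compound 2 to compound 3 (1.22 log units; beyond the scatter), the first readable sign that the dose responds to what this position carries. Carrying an aryl group is not enough on its own to set the dose: 4-fluorophenyl in place of 2-chlorophenyl at the same place gives an at least 6.6-fold lower number from compound 1 to compound 3 (0.82 log units; beyond the scatter), a difference between the two aryl groups that the earlier pair of limits could not reveal. Both steps start from a compound known only as a limit, so their true sizes may be larger still.

The compounds shown leave open whether the gain belongs to the fluorine, to its place on the ring or to the chlorine of compound 1 going, and an unsubstituted phenyl, a 2-fluorophenyl or a 4-chlorophenyl on the same carbon would separate these readings. They also leave open how a longer chain or a pyridine ring at this place would compare with 4-fluorophenyl.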